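This account rests on a few compounds, and the source may have more. Where it says the series, first, only, none or still open, it means among the compounds named here.

Measured compounds:
- Compound 1, `CCN(CC)CN1C(=O)/C(=N/NC(N)=S)c2ccccc21`: in an ADME assay on HeLa cells (Homo sapiens) for cytotoxicity (a higher number here means that more compound is tolerated, a lower number that less compound is tolerated), compound 1 gives > 100000 nM, which is a limit of the assay rather than a number.
- Compound 2, `CCN(CC)CN1C(=O)/C(=N/NC(=S)Nc2ccc(Cl)cc2)c2cc(Cl)ccc21`: in this assay compound 2 gives 100000 nM.

For the measured compounds named here, compound 2 therefore holds the only actual number in this assay. The value of compound 1 is only a limit of the assay (the limit of > 100000 nM in this assay, at which 1 of the 2 values shown sits). Going by the values given here, the two compounds differ in more than one place, so no single step between them can be measured, and nothing yet shows how large a change of one group moves the read-out.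

Compound 3, `CCN(CC)CN1C(=O)/C(=N/NC(=S)Nc2ccc(C)cc2)c2cc(Cl)ccc21`, differs from compound 2 in one place: methyl in place of chloro on an aromatic carbon. Among the compounds with values here, with no measured step to lean on, the expected change from compound 2 to compound 3 is no change at the digits printed from compound 2 to compound 3 (within the scatter), that is, none beyond the usual scatter and in no particular direction. Compound 3 is accordingly estimated at 100000 nM, within a range from 40000 nM to 250000 nM.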

Compound 3, minimum cytotoxic concentration: >= 4000 nM
Compound 3: only a limit was reported; the forecaster's own chance of this, stated with the estimate: 40%; the middle value lies beyond the limit too.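

Compound 3 gives >= 4000 nM in this assay and this is a limit of the assay, not a number, so no size can be read for the step between compound 2 and compound 3. Still open, from the compounds shown here alone, is how far any single change of group moves the read-out.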